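Swapping a Methyl for Pyridin-2-yl in an Amide Series

This account rests on a few compounds, and the source may have more. Where it says the series, first, only, none or still open, it means among the compounds named here.

compound 1 `CCc1cnc(NC(=O)CCC2CCCCC2)s1` — "not determined" (no result reported)
compound 2 `O=C(Nc1ncc(Cc2cc3sccc3s2)s1)C1CCCCC1` — "not determined" (no result reported)
compound 3 `O=C(Nc1ncc(Cc2cccc3sccc23)s1)C1CCCCC1` — > 40000 nM

Three compounds have been through an ADME assay on P388D1 cells (Mus musculus) for cytotoxicity, read by fluorescence and resazurin assay, with a stated time of 72 h (on this read-out lower numbers stand for stronger inhibition and higher numbers for weaker inhibition), so far, and only one of them came back with an entry that can be read at all. Compound 1 carries no number in this assay. Compound 2 likewise has no number. Compound 3 shows only a limit of the assay in this assay, not a measured number. Among the measured compounds shown here, compound 1 therefore stands nowhere on a scale: there is no value to place it against, and the one value that exists in the set is itself an edge rather than a point, as the limit of > 40000 nM in this assay, at which 1 of the 3 values shown sits, records.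

Compound 4 is `O=C(CCC1CCCCC1)Nc1ncc(Cc2ccccn2)s1`. It arises from compound 1 by a single change: pyridin-2-yl in place of methyl on a saturated chain carbon bound to an aromatic carbon. For the measured compounds named here, no measured pair in this set shares that change, so nothing here tells how large a step in this assay it should bring or in which direction; no shift beyond the scatter is expected on the evidence available. On that footing, compound 4 is expected to sit near 40000 nM in this assay, with a likely span from 15000 nM to 100000 nM.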

Compound 4, half-maximal inhibitory concentration: > 40000 nM
Compound 4 gave a limit, no number; the forecaster's own chance of this, stated with the estimate: 70%; the middle value lies on the limit itself.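

In this assay compound 4 gives > 40000 nM, which is a limit of the assay and not a number. Compound 1 has no number there, so no step can be read between compound 1 and compound 4. As far as these compounds go, whether pyridin-2-yl in place of methyl shifts this read-out at all, and in which direction, stays open.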